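The compounds below may be only part of what the source reports. "The series", "measured", "known", "first", "only" and "open" are said of these compounds alone.

Compound 2 `CCN1CCN(c2cccc3c2CN([C@H](CCCNS(=O)(=O)c2c[nH]cn2)c2ccc(OC)c(OC)c2)C3=O)CC1` gives 25 nM in an assay on RMS13 cells for displacement of a labelled ligand from Urotensin-2 receptor (Homo sapiens), read by scintillation proximity assay (a lower number here means a stronger inhibitor, a higher number a weaker inhibitor), the lower of the two numbers recorded there; compound 1 `CCN1CCN(c2cccc3c2C(=O)N([C@H](CCCNS(=O)(=O)c2cn(C)c(C)n2)c2ccc(OC)c(OC)c2)C3=O)CC1` gives 97 nM, a gap that lies beyond the scatter. Compound 3 `COc1ccc([C@@H](CCCN(C)S(=O)(=O)c2cccs2)N2Cc3c(cccc3N3CCN(C)CC3)C2=O)cc1OC` is reported only as a limit, < 6 nM, and the limit of < 6 nM in this assay, at which 1 of the 3 values shown sits, marks that limit. Compound 4 `CCN1CCN(c2cccc3c2CN([C@H](CCCNc2cncc(OC)n2)c2ccc(OC)c(OC)c2)C3=O)CC1` differs from compound 2 by 6-methoxypyrazin-2-yl in place of (1H-imidazol-4-yl)sulfonyl on an amine nitrogen. Among the measured compounds shown here, no pair of measured compounds shows this change, so its size is open; the sulfonyl group is lost entirely, and the step from compound 2 to compound 4 is expected to be a 3.2-fold higher number from compound 2 to compound 4 (0.51 log units; beyond the scatter), toward a weaker inhibitor. Compound 4 is therefore estimated at 80 nM in this assay, with a likely range from 20 nM to 400 nM.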

Compound 4, inhibition constant: 8 nM
For compound 4 the middle estimate is 10-fold (1.00 log units) above the measured one, outside the stated range (below it).
By their numbers in this assay, from the lowest: compound 4; then compound 2; then compound 1. At a limit, below all of these: compound 3.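

Replacing (1H-imidazol-4-yl)sulfonyl with 6-methoxypyrazin-2-yl on the amine nitrogen gives a 3.1-fold lower number from compound 2 to compound 4 (0.49 log units; beyond the scatter) in this assay. The earlier compounds shown here all carry a sulfonyl group at this place, so only this result shows that the position tolerates its complete loss, and that a six-membered aromatic ring can stand there without weakening the compound.

Whether the methoxy group matters stays open, as a plain pyrazin-2-yl or phenyl group does not appear among these compounds. Further gains may be hard to size because readings in this assay can end at a limit: the limit of < 6 nM in this assay, at which 1 of the 4 values shown sits.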